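This account rests on a few compounds, and the source may have more. Where it says the series, first, only, none or still open, it means among the compounds named here.

Measured compounds:
compound 1, `CC[C@@H]1C(=O)N(C)c2cnc(-n3ccc4cc(C(=O)NC)ccc43)nc2N1C1CCCC1`, 842 nM
compound 2, `CCCNC(=O)c1ccc2c(ccn2-c2ncc3c(n2)N(C2CCCC2)[C@H](CC)C(=O)N3C)c1`, 689 nM
compound 3, `CCCCNC(=O)c1ccc2c(ccn2-c2ncc3c(n2)N(c2ccn(C)n2)C(CC)C(=O)N3C)c1`, 8670 nM

In a functional assay on Huh-7 cells (Homo sapiens) for antiproliferative activity, read by CCK-8 assay, with a stated time of 72 h (on this read-out higher numbers stand for weaker inhibition of growth and lower numbers for stronger inhibition of growth), compound 2 gives 689 nM and compound 1 gives 842 nM. Among the compounds with values here, the one change between them is hydrogen in place of ethyl on a saturated chain carbon bound to an amide-type nitrogen, and it made a 1.2-fold higher number from compound 2 to compound 1 (0.09 log units; within the scatter). Compound 3 gives 8670 nM in this assay; the difference between its core and the core of compound 2 is not broken down here. Compound 4, `CCNC(=O)c1ccc2c(ccn2-c2ncc3c(n2)N(c2ccn(C)n2)C(CC)C(=O)N3C)c1`, is not yet measured; it differs from compound 3 by hydrogen in place of ethyl on a saturated chain carbon, two bonds along the chain from an amide-type nitrogen. This is the same kind of change as that from compound 2 to compound 1, not the same one: there the carbon was bound to an amide-type nitrogen, here it lies two bonds along the chain from one. Since the earlier step stayed within the scatter, compound 4 is expected to stay close to compound 3, with an estimated step of a 1.1-fold higher number from compound 3 to compound 4 (0.04 log units; within the scatter). Compound 4 is estimated at 9500 nM, between 4000 nM and 22000 nM, in this assay.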

Compound 4, concentration for 50% growth inhibition: 20300 nM
The estimate for compound 4 lay 2.1-fold (0.33 log units) below the measured number; low and high end bracket the measured number.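

In this assay, cutting the amide chain from butyl to ethyl gave a 2.3-fold higher number from compound 3 to compound 4 (0.37 log units; beyond the scatter). Set beside the earlier step on the other core, the same change shows no difference between the two cores that exceeds the scatter: the same change on two cores in this assay, a 1.2-fold higher number (0.09 log units; within the scatter) from compound 2 to compound 1 and a 2.3-fold higher number (0.37 log units; beyond the scatter) from compound 3 to compound 4, 1.9-fold (0.28 log units) apart, within the scatter of two such steps. Within the data shown here, this supports carrying the change between these two cores, but it rests on only two pairs, one step within the scatter and one beyond it, and it does not show that the step would keep its size on any further core.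

The compounds shown leave open how a chain longer than butyl would read in this assay. They also leave open how a chain carrying an amine or a carboxylic acid would read.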